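An Aryl Exchange at the Limit of Stability

The compounds below may be only part of what the source reports. "The series", "measured", "known", "first", "only" and "open" are said of these compounds alone.

Of the compounds shown here, three have been measured in an ADME assay on microsomes from liver (Homo sapiens) for metabolic stability, read by LC-MS, with NADPH named in the record, with a stated time of 60 min, tested at 1 uM, in the absence of a further agent (a higher number here means that more of the compound is left, a lower number that less of the compound is left), and all three stand at the same limit. Compound 1 `COc1ccc(-c2c(C)oc3c(N4CC[C@@H](NC(C)=O)C4)cc(C)nc23)cc1OC` gives > 95% as a limit and not a number. Compound 2 `CC(=O)N[C@@H]1CCN(c2cc(C)nn3c(-c4ccccc4)c(C)nc23)C1` gives > 95% as a limit too. On these data alone, compound 3 `CC(=O)N[C@@H]1CCN(c2cc(C)nn3c(-c4ccc(C(F)(F)F)cc4)c(C)nc23)C1` gives > 95% as a limit as well, so its exact standing is unknown. The series thus shows the limit of > 95% in this assay, at which 3 of the 3 values shown sit, and nothing finer.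

Compound 4 `COc1ccc(-c2c(C)nc3c(N4CC[C@@H](NC(C)=O)C4)cc(C)nn23)cc1F` alters the aryl group of compound 3 as follows: 3-fluoro-4-methoxyphenyl in place of 4-(trifluoromethyl)phenyl on an aromatic carbon with 3-fluoro-4-methoxyphenyl in place of 4-(trifluoromethyl)phenyl on an aromatic carbon. For the measured compounds named here, the one measured step on this aryl group is a step that the two limits leave unreadable from compound 2 to compound 3 and gives no size to carry over. Compound 1 has methoxy groups on its aryl ring, on a different core, and gives > 95% as a limit. On that basis, no step beyond the scatter is expected. In this assay the expected step is a number at least 2 percentage points lower from compound 3 to compound 4 (that floor lies within the scatter) and it is only an estimate. For compound 4 the estimated value is 93% with an expected range from 78% to 100% as its upper end.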

Compound 4, percent of the compound remaining: > 95%
Compound 4: a limit, no number (the forecaster's own chance of this, stated with the estimate: 55%); middle value at least 2 percentage points from the limit.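

In this assay compound 4 gives > 95%, a limit and not a number. No new step can be read between compound 4 and either compound 2 or compound 3. The compounds shown leave open whether these aryl exchanges change the amount of compound left at all: the limit of > 95% in this assay, at which 4 of the 4 values shown sit.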